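A few compounds are considered here, and "the series" means these few. Any claim that something is new, unique, unknown or untested is made for them only; others in the source may bear on it.

Measured compounds in a functional assay on HEK293 cells for negative allosteric modulation of metabotropic glutamate receptor 5 (Homo sapiens), read by calcium flux, with a stated time of 20 min; a lower number here means a stronger inhibitor, a higher number a weaker inhibitor:

compound 1, `O=C(c1ccccc1)N1CCn2nc(-c3ccc(F)cn3)cc2C1`: 164 nM
compound 2, `O=C(c1cccc(Cl)c1)N1CCn2nc(-c3ccc(F)cn3)cc2C1`: 150 nM
compound 3, `Cc1cccc(C(=O)N2CCn3nc(-c4ccc(F)cn4)cc3C2)c1`: 150 nM

Compound 3 stands level with compound 2 at the digits given, and the two share the lower of the three numbers; compound 1 is the furthest from compound 3, yet a 1.1-fold lower number from compound 1 to compound 3 (0.04 log units; within the scatter), so all three values lie within the scatter of one another. The other two single-point changes on the same phenyl ring read the same way: a 1.1-fold lower number from compound 1 to compound 2 (0.04 log units; within the scatter) and no change at the digits printed from compound 2 to compound 3 (within the scatter).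

Compound 4, `COc1cccc(C(=O)N2CCn3nc(-c4ccc(F)cn4)cc3C2)c1`, differs from compound 3 by methoxy in place of methyl on an aromatic carbon. Within the data shown here, the steps that bear on it are those that vary this same aromatic carbon: hydrogen to chloro, hydrogen to methyl and chloro to methyl, none of which moved the number beyond the scatter. Among the measured compounds shown here, no compound with an oxygen-bearing substituent at this carbon has been measured, so the hydrogen-bond acceptor that enters is untested here. On the steps available, the expectation for this assay is a step of no change at the digits printed from compound 3 to compound 4 (within the scatter), that is, no change beyond the scatter in either direction. Compound 4 is therefore expected at 150 nM, with a range from 75 nM to 300 nM.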

Compound 4, half-maximal inhibitory concentration: 482 nM
Compound 4: the middle estimate sits 3.2-fold (0.51 log units) below what was measured, and the stated range ends below it.
By their numbers in this assay, from the lowest: compounds 2, 3 and 1 (each within the scatter of the next); then compound 4.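

In this assay, the aromatic carbon meta to a large group proves sensitive to the identity of its substituent: methoxy gives a 2.9-fold higher number from compound 1 to compound 4 (0.47 log units; beyond the scatter), with a 3.2-fold higher number from compound 2 to compound 4 (0.51 log units; beyond the scatter) and a 3.2-fold higher number from compound 3 to compound 4 (0.51 log units; beyond the scatter). Hydrogen, chloro and methyl remain within the scatter of one another at this carbon, so methoxy alone separates from the set, in the direction of a weaker inhibitor, and the change from 3-methylphenyl to 3-methoxyphenyl shows that this position does not accept every small substituent equally. Nothing measured on these compounds accounts for the step, so the roles of the added oxygen and hydrogen-bond acceptor remain unassigned.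

The compounds shown do not separate the oxygen from the greater size of methoxy: ethyl at this carbon would keep an all-carbon substituent, while hydroxy would keep an oxygen without the methyl. Also open, as far as these compounds go, is whether the step is specific to this carbon or would recur with methoxy elsewhere on the phenyl ring, and how an amine or a longer ether such as ethoxy would read here.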